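Hydroxyphenyl amide in place of methoxyphenyl on an inactive series

This account rests on a few compounds, and the source may have more. Where it says the series, first, only, none or still open, it means among the compounds named here.

Compound 2 `COc1ccccc1C(=O)Nc1ccc(Sc2nc3ccccc3s2)cc1` has been tested in an assay on isolated protein for inhibition of thiosulfate sulfurtransferase (Homo sapiens), with a stated time of 60 min, in the absence of a further agent; a higher number here means a weaker inhibitor, a lower number a stronger inhibitor. For compound 2 the result is only the limit > 100000 nM, not a number. Compound 3 `COc1ccccc1C(=O)Nc1ccc(Sc2nc3ccccc3s2)c(Cl)c1` carries chloro in place of hydrogen on an aromatic carbon; compound 3 also stops at the limit > 100000 nM in this assay. The step that the two limits leave unreadable from compound 2 to compound 3 is therefore unreadable. Compound 1 `O=C(Nc1ccccc1)c1cc(Br)ccc1O`, a simpler hydroxyphenyl amide without the benzothiazolylthio part, likewise reaches only the limit > 100000 nM in this assay. All three results sit at the limit of > 100000 nM in this assay, at which 3 of the 3 values shown sit, so compound 2 stands at the limit and cannot be ranked against compound 1 or compound 3.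

Compound 4 `O=C(Nc1ccc(Sc2nc3ccccc3s2)cc1)c1cc(Br)cc(Br)c1O` is not yet measured. It differs from compound 2 by 3,5-dibromo-2-hydroxyphenyl in place of 2-methoxyphenyl on a carbonyl carbon. Going by the values given here, no measured step bears directly on this change; the one measured step, a step that the two limits leave unreadable from compound 2 to compound 3, concerns a different place and is itself unreadable between two limits. Compound 1 shows only that a hydroxyphenyl amide without the benzothiazolylthio part sits at the limit > 100000 nM. With nothing readable to build on, compound 4 is expected to remain at or near the limit, so the step of a number no higher from compound 2 to compound 4 (the limit leaves the size open) is expected to be none beyond the scatter. The estimate for compound 4 in this assay is 100000 nM, with a range from 20000 nM to 500000 nM.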

Compound 4, half-maximal inhibitory concentration: > 100000 nM
Compound 4 was reported as a limit; the forecaster's own chance of this, stated with the estimate: 70%; the middle value sits exactly at the limit.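

In this assay compound 4 gives > 100000 nM, which is a limit and not a number. Going by these compounds alone, no step from compound 2 to compound 4 can be read, because both results stop at the same limit: the limit of > 100000 nM in this assay, at which 4 of the 4 values shown sit.

The compounds shown leave open whether any of these structures inhibits measurably, and how 3,5-dibromo-2-hydroxyphenyl and 2-methoxyphenyl rank.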